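Cyclobutyl replaces methoxyethyl on the chain at the ring nitrogen

The source may report more compounds than this note shows. Statements on the series, on what has been measured and on what is new or still open speak of the compounds shown alone.

Of the compounds shown here, three sharing one core have been measured in a functional assay on MCF7 cells (Homo sapiens) for cytotoxicity; on this read-out higher numbers stand for an effect only at larger amounts of compound and lower numbers for an effect already at smaller amounts. Compound 1 `COc1cc(Cc2nc3c(N)ncnc3n2CCO)cc(OC)c1OC` gives 222000000 nM, compound 2 `CCC(CO)CCn1c(Cc2cc(OC)c(OC)c(OC)c2)nc2c(N)ncnc21` gives 19200000 nM and compound 3 `COCCCn1c(Cc2cc(OC)c(OC)c(OC)c2)nc2c(N)nc(F)nc21` gives 72600000 nM. Compound 3 stands second highest of the three: its number lies beyond the scatter of compound 1 on one side and of compound 2 on the other. Compound 4 `COc1cc(Cc2nc3c(N)nc(F)nc3n2CC2CCC2)cc(OC)c1OC` differs from compound 3 in one place: cyclobutyl in place of 2-methoxyethyl on a saturated chain carbon bound to an aromatic nitrogen.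

Among the measured compounds shown here, only one step in the set changes the chain on the aromatic nitrogen, and that step, a 12-fold lower number from compound 1 to compound 2 (1.06 log units; beyond the scatter), went to a lower number. Both steps replace a small oxygen-bearing group on that chain with a larger carbon piece, so a lowering of some size is expected for compound 4 as well, though a different partner group and a different core substituent make it uncertain. The step expected from compound 3 to compound 4 is a 2.4-fold lower number from compound 3 to compound 4 (0.38 log units; beyond the scatter). Compound 4 is therefore estimated at 30000000 nM, within a range of 8000000 nM to 150000000 nM.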

Compound 4, half-maximal effective concentration: 109000000 nM
Beside the measured number, compound 4's estimate is 3.6-fold (0.56 log units) below it; the range from low to high includes it.
By their numbers in this assay, from the lowest: compound 2; then compounds 3 and 4 (each within the scatter of the next); then compound 1.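

In this assay, replacing 2-methoxyethyl with cyclobutyl on a saturated chain carbon bound to an aromatic nitrogen gives a 1.5-fold higher number from compound 3 to compound 4 (0.18 log units; within the scatter), so this read-out does not separate the two groups. The two groups have the same count of heavy atoms, yet the chain oxygen is lost and a four-membered carbon ring enters, and the number still stays within the scatter. Among the compounds shown here, this differs from the one earlier step on this chain, a 12-fold lower number from compound 1 to compound 2 (1.06 log units; beyond the scatter), and no measurement available here explains why compound 3 and compound 4 read alike.

On these data alone, whether cyclobutyl would read the same way on the core of compound 1 remains open. Also open, as far as these compounds go, is how an amine, a carboxylic acid or a longer chain would fare at this position.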